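Fluorines in place of methoxy on the chalcone aryl

This account rests on a few compounds, and the source may have more. Where it says the series, first, only, none or still open, it means among the compounds named here.

Measured so far:
compound 1, `COc1cc(-c2cc(/C=C/C(=O)c3ccc(Cl)c(Cl)c3)[nH]n2)cc(OC)c1OC`: 90%
compound 2, `COc1ccc(C(=O)/C=C/c2cc(-c3cc(OC)c(OC)c(OC)c3)n[nH]2)cc1`: 96%

In a functional assay on T47D cells (Homo sapiens) for cytotoxicity, read by sulforhodamine B assay, with a stated time of 48 h, tested at 0.01 uM (on this read-out lower numbers stand for a stronger effect and higher numbers for a weaker effect at the one concentration tested), compound 2 gives 96%, the upper of the two numbers, with compound 1 nearest; the step of a number 6 percentage points higher from compound 1 to compound 2 (within the scatter) lies within the scatter, so the two cannot be told apart. Compound 3, `COc1cc(-c2cc(/C=C/C(=O)c3ccc(F)c(F)c3)[nH]n2)cc(OC)c1OC`, differs from compound 2 by 3,4-difluorophenyl in place of 4-methoxyphenyl on a carbonyl carbon. For the measured compounds named here, the only step that bears on this position, a number 6 percentage points higher from compound 1 to compound 2 (within the scatter), exchanged one aryl for another at the same carbonyl carbon and stayed within the scatter, so no step beyond the scatter is expected for a number 3 percentage points lower from compound 2 to compound 3 (within the scatter). Compound 3 is therefore estimated at 93%, within 82% to 102%.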

Compound 3, a percentage reported as activity, at one concentration (the size of the read-out at that concentration, not a potency): 95%
Estimate against measurement, compound 3: 2 percentage points below; low and high end bracket the measured number.
By their numbers in this assay, from the lowest: compounds 1, 3 and 2 (each within the scatter of the next).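

In this assay, placing 3,4-difluorophenyl on the carbonyl carbon gives a number 1 percentage points lower from compound 2 to compound 3 (within the scatter) and a number 5 percentage points higher from compound 1 to compound 3 (within the scatter). With 3,4-dichlorophenyl, 4-methoxyphenyl and 3,4-difluorophenyl now compared at this carbonyl carbon, no exchange among the three leaves the scatter, so this read-out does not separate them. Nothing at hand offers an explanation for this result. Going by these compounds, it remains open whether an aryl group carrying an amine or a carboxylic acid would move the number at this position. On these data alone, whether these three compounds would separate at another concentration also remains open.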